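A few compounds are considered here, and "the series" means these few. Any claim that something is new, unique, unknown or untested is made for them only; others in the source may bear on it.

Values in a functional assay on HeLa cells (Homo sapiens) for cytotoxicity; on this read-out higher numbers stand for weaker inhibition and lower numbers for stronger inhibition:
- Compound 1 `CC1=CCC[C@H]2[C@](C)(CC3=CC(=O)C(SC(C)(C)C)=CC3=O)[C@@H](C)CC[C@]12C`: 37000 nM
- Compound 2 `CCCCCCCCSC1=CC(=O)C(C[C@]2(C)[C@@H](C)CC[C@]3(C)C(C)=CCC[C@@H]23)=CC1=O`: > 100000 nM, a limit

Compound 2 has no number of its own, only a limit: the limit of > 100000 nM in this assay, at which 1 of the 2 values shown sits. Compound 3 `CC1=CCC[C@H]2[C@](C)(CC3=CC(=O)C=CC3=O)[C@@H](C)CC[C@]12C` differs from it by hydrogen in place of octylsulfanyl on a double-bonded ring carbon, with hydrogen in place of octylsulfanyl on a double-bonded ring carbon. For the measured compounds named here, the one measured step is an at least 2.7-fold higher number from compound 1 to compound 2 (0.43 log units; beyond the scatter), a change beyond the scatter, with octyl in place of tert-butyl on a sulfur. It bears on this change only indirectly, since neither measured compound lacks the sulfur group. Shortening the group on sulfur went with lower numbers, so a move towards lower numbers is expected in this assay. The expected step is an at least 6.6-fold lower number from compound 2 to compound 3 (0.82 log units; beyond the scatter). The estimate for compound 3 is 15000 nM, within an expected range from 4000 nM to 60000 nM.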

Compound 3, half-maximal inhibitory concentration: 26800 nM
Estimate against measurement, compound 3: 1.8-fold (0.25 log units) below; the range from low to high includes it.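

In this assay hydrogen in place of octylsulfanyl gives an at least 3.7-fold lower number from compound 2 to compound 3 (0.57 log units; beyond the scatter) and so shows that this double-bonded ring carbon needs no sulfur group for the activity seen. Hydrogen in place of (tert-butyl)sulfanyl gives a 1.4-fold lower number from compound 1 to compound 3 (0.14 log units; within the scatter) and thus no change beyond the scatter, which sets octylsulfanyl apart from the other two groups. The value of compound 2 is a limit, not a number: the limit of > 100000 nM in this assay, at which 1 of the 3 values shown sits. The compounds shown leave open how a butyl chain on the sulfur would behave. Going by these compounds, whether an amine or a hydroxyl group at this carbon would give lower numbers also stays open.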